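The source may report more compounds than this note shows. Statements on the series, on what has been measured and on what is new or still open speak of the compounds shown alone.

In a functional assay on WiDr cells (Homo sapiens) for inhibition, read by sulforhodamine B assay, with a stated time of 48 h (a lower number here means a stronger inhibitor of growth, a higher number a weaker inhibitor of growth), compound 1 `COC(=O)[C@@]1(C)CC[C@@H]2C3=C1CC[C@@H](C)[C@]3(C)C[C@@H]1c3ccccc3N[C@H]21` gives 50000 nM, compound 2 `COC(=O)[C@@]1(C)CC[C@@H]2C3=C1CC[C@@H](C)[C@]3(C)C[C@@H]1c3cc(Br)ccc3N[C@H]21` gives 55000 nM, and compound 3 `COC(=O)[C@@]1(C)CC[C@@H]2C3=C1CC[C@@H](C)[C@]3(C)C[C@@H]1c3cc(Cl)ccc3N[C@H]21` gives 48000 nM. Compound 3 carries the lowest of the three numbers, yet every gap to its companions lies within the scatter: the steps of a 1.0-fold lower number from compound 1 to compound 3 (0.02 log units; within the scatter), a 1.1-fold higher number from compound 1 to compound 2 (0.04 log units; within the scatter) and a 1.1-fold lower number from compound 2 to compound 3 (0.06 log units; within the scatter) are all small. Compound 4 `COC(=O)[C@@]1(C)CC[C@@H]2C3=C1CC[C@@H](C)[C@]3(C)C[C@@H]1c3cc(OC)ccc3N[C@H]21` differs from compound 3 by methoxy in place of chloro on an aromatic carbon. The three measured steps show that swapping the group at this position has so far left this assay unmoved, so the move from chloro to methoxy is expected to give no step beyond the scatter, and for compound 4 the expected step is a 1.0-fold higher number from compound 3 to compound 4 (0.02 log units; within the scatter). Compound 4 is therefore estimated at 50000 nM, with a range from 25000 nM to 100000 nM.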

Compound 4, concentration for 50% growth inhibition: 25000 nM
Compound 4: the middle estimate sits 2.0-fold (0.30 log units) above what was measured; the range from low to high includes it.
By their numbers in this assay, from the lowest: compounds 4, 3, 1 and 2 (each within the scatter of the next, the first and the last beyond it).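

In this assay, methoxy is the only group shown at this position to give a step beyond the scatter, and only against bromo (a 2.2-fold lower number from compound 2 to compound 4 (0.34 log units; beyond the scatter)). Against chloro (a 1.9-fold lower number from compound 3 to compound 4 (0.28 log units; within the scatter)) and against hydrogen (a 2.0-fold lower number from compound 1 to compound 4 (0.30 log units; within the scatter)) it stays within the scatter, so the position is no longer wholly silent, but the effect is modest. Nothing available explains this step. The compounds shown leave open whether an amine or a carboxylic acid at this position would give a larger step. They also leave open whether a longer chain in place of methoxy would.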